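Swapping hydroxy for methyl on a hydrazide series

The source may hold more compounds than are shown below. What is called first, only, known or untested is meant among the compounds shown, and "the series" means these compounds.

Compound 1 `CCc1ccccc1NNC(=O)CC[C@H](N)C(=O)O`: 17.1 ug/mL
Compound 2 `N[C@@H](CCC(=O)NNc1ccccc1F)C(=O)O`: 10.9 ug/mL
Compound 3 `N[C@@H](CCC(=O)NNc1cccc(O)c1)C(=O)O`: 10.7 ug/mL

In a functional assay, read by spectrophotometry, with a stated time of 30 min (on this read-out lower numbers stand for stronger inhibition and higher numbers for weaker inhibition), the three values lie within the scatter of one another, so compound 3, at 10.7 ug/mL, stands level with compound 1 and compound 2. Compound 4 `Cc1cccc(NNC(=O)CC[C@H](N)C(=O)O)c1` differs from compound 3 by methyl in place of hydroxy on an aromatic carbon. For the measured compounds named here, the only measured single change, a 1.6-fold lower number from compound 1 to compound 2 (0.20 log units; within the scatter), puts fluoro in place of ethyl. It involves other groups, so it bears on this change only indirectly, and it stayed within the scatter. On that evidence, no shift beyond the scatter is expected in this assay, and the expected step is a 1.1-fold higher number from compound 3 to compound 4 (0.05 log units; within the scatter). Compound 4 is estimated at 12 ug/mL, with an expected range of 6.5 ug/mL to 22 ug/mL.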

Compound 4, half-maximal inhibitory concentration: 10.1 ug/mL
Compound 4: the middle estimate sits 1.2-fold (0.07 log units) above what was measured, and the stated range covers the measured number.
By their numbers in this assay, from the lowest: compounds 4, 3, 2 and 1 (each within the scatter of the next).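

In this assay, for the compounds shown here, the change at this place, on an aromatic carbon meta to a large group, gives a 1.1-fold lower number from compound 3 to compound 4 (0.03 log units; within the scatter) and is the first direct reading of methyl in place of hydroxy. The count of hydrogen-bond donors and acceptors falls from one each to none at this carbon, and the number stays within the scatter. No measurement shown offers an explanation for this result.

The compounds shown leave open how an amine, a methoxy group or a carboxylic acid would read at the same carbon.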